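Ring swap on the chain end in a fibrosis reporter

A few compounds are considered here, and "the series" means these few. Any claim that something is new, unique, unknown or untested is made for them only; others in the source may bear on it.

Three compounds share a core and a long chain ending in a charged ring, and differ in how the chain and the core are joined. Compound 1 `Cc1cc(-n2cc(C(=O)Nc3cc(F)cc(F)c3)c(=O)c3ccc(N(C)C)nc32)ccc1OCCCCCCC[N+]1(C)CCN(C)CC1` and compound 2 `Cc1ccc(-n2cc(C(=O)Nc3cc(F)cc(F)c3)c(=O)c3ccc(N(C)C)nc32)cc1OCCCCCCC[N+]1(C)CCN(C)CC1` carry the same atoms joined differently; the difference between the two cores is not broken down here. In an assay on LX2 cells for inhibition of COL1A1 promoter (Homo sapiens), read by a luciferase reporter, with a stated time of 24 h, tested at 50 uM (a higher number here means a stronger effect of the compound at the concentration tested, a lower number a weaker effect), compound 1 gives 32% and compound 2 gives 25%, two numbers within the usual scatter of each other. Compound 3 `CC[N+]1(CCCCCCCOc2ccc(-n3cc(C(=O)Nc4cc(F)cc(F)c4)c(=O)c4ccc(N(C)C)nc43)cc2C)CCCC1` differs from compound 1 by a group of 7 heavy atoms (6 carbon, 1 nitrogen; one five-membered non-aromatic ring with 1 hetero atom) in place of a group of 8 heavy atoms (6 carbon, 2 nitrogen; one six-membered non-aromatic ring with 2 hetero atoms), on a saturated chain carbon, seven bonds along the chain from an oxygen on an aromatic ring. In this assay compound 3 gives 82.5%, and this step raised the read-out a number 50.5 percentage points higher from compound 1 to compound 3 (beyond the scatter).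

Compound 4 `CC[N+]1(CCCCCCCOc2cc(-n3cc(C(=O)Nc4cc(F)cc(F)c4)c(=O)c4ccc(N(C)C)nc43)ccc2C)CCCC1` has not yet been measured in this assay. It differs from compound 2 by a group of 7 heavy atoms (6 carbon, 1 nitrogen; one five-membered non-aromatic ring with 1 hetero atom) in place of a group of 8 heavy atoms (6 carbon, 2 nitrogen; one six-membered non-aromatic ring with 2 hetero atoms), on a saturated chain carbon, seven bonds along the chain from an oxygen on an aromatic ring, the same change, at the same place, as that from compound 1 to compound 3. Among the compounds with values here, because the one measured instance of this change gave a number 50.5 percentage points higher from compound 1 to compound 3 (beyond the scatter), a step of similar size is expected, namely a number 45 percentage points higher from compound 2 to compound 4 (beyond the scatter), with the caveat that a single pair is a thin basis. Compound 4 is therefore estimated at 70% in this assay, likely between 45% and 90%.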

Compound 4, a percentage reported as inhibition, at one concentration (the size of the read-out at that concentration, not a potency): 81.4%
For compound 4 the middle estimate is 11.4 percentage points below the measured one, and the stated range covers the measured number.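

In this assay, replacing the six-membered non-aromatic ring with 2 hetero atoms at the chain end by the five-membered non-aromatic ring with 1 hetero atom gave a number 56.4 percentage points higher from compound 2 to compound 4 (beyond the scatter), so the change carried over to the second core. Set beside the first instance, the two steps match in size: the same change on two cores in this assay, a number 50.5 percentage points higher (beyond the scatter) from compound 1 to compound 3 and a number 56.4 percentage points higher (beyond the scatter) from compound 2 to compound 4, 5.9 percentage points apart, within the scatter of two such steps For these two cores, which carry the same atoms joined differently, this shows a gain of similar size, but it rests on only two pairs at a single concentration and shows neither a potency, nor why the read-out rises, nor that the gain would hold on a different core.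

The compounds shown leave open whether other rings at the chain end, such as a piperidine or a morpholine, would give a similar read-out. They also leave open how the read-out would respond to a shorter or longer chain between the oxygen and the charged ring.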